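Swapping the butyl arm for a difluorobenzyl on the core

The source may report more compounds than this note shows. Statements on the series, on what has been measured and on what is new or still open speak of the compounds shown alone.

Compound 1: `CCCCc1cnc(CCc2ccc(-c3ccccc3C(=O)O)cc2)[nH]1`, 93 nM
Compound 2: `CCCCc1cnc(C(CCC)Cc2ccc(-c3ccccc3C(=O)O)cc2)[nH]1`, 165 nM
Compound 3: `CCCCc1cnc(/C=C/c2ccc(-c3ccccc3C(=O)O)cc2)[nH]1`, 10000 nM

In an in vitro functional assay on cells for agonist activity at Bombesin receptor subtype-3 (Mus musculus), read by luminescence and calcium flux (a higher number here means that more compound is needed for the effect, a lower number that less compound is needed), compound 1 gives the lowest of the three numbers, with compound 2 nearby and compound 3 far higher. Compound 4 is `O=C(O)c1ccccc1-c1ccc(CCc2ncc(Cc3cccc(F)c3F)[nH]2)cc1`; it differs from compound 1 by 2,3-difluorophenyl in place of propyl on a saturated chain carbon bound to an aromatic carbon, which cut one bond further out reads butyl to 2,3-difluorobenzyl. For the measured compounds named here, no measured step touches this arm. Going by the values given here, the only single change recorded, a 1.8-fold higher number from compound 1 to compound 2 (0.25 log units; within the scatter), lies elsewhere and stays within the scatter, so it gives no direction for the new change. A small step is therefore expected for compound 4, a 1.6-fold higher number from compound 1 to compound 4 (0.21 log units; within the scatter), and its value is estimated at 150 nM with a range from 30 nM to 800 nM.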

Compound 4, half-maximal effective concentration: 8 nM
The estimate for compound 4 lay 19-fold (1.27 log units) above the measured number, outside the stated range (below it).
By their numbers in this assay, from the lowest: compound 4; then compounds 1 and 2 (each within the scatter of the next); then compound 3.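

The butyl arm of compound 1 is open to change: with 2,3-difluorobenzyl in its place there is a 12-fold lower number from compound 1 to compound 4 (1.07 log units; beyond the scatter), so less compound is needed for the effect. This position therefore accepts an arm carrying an aromatic ring, and changing it moves the number far more than the added propyl of compound 2 did. Nothing available here explains why this arm gives the lower number.

The compounds shown do not separate the part played by the ring from that of its two fluorines. An unsubstituted benzyl or a cyclohexylmethyl arm on the same core would address that question.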